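Chloro for fluoro: from compound 2 to compound 3

This account rests on a few compounds, and the source may have more. Where it says the series, first, only, none or still open, it means among the compounds named here.

Compound 1 `O=C(Nc1cc(Cl)cc2cccnc12)c1cnccn1` carries chloro, and in a functional assay on BXPC-3 cells (Homo sapiens) for inhibition, read by MTT assay, with a stated time of 72 h (a higher number here means a weaker inhibitor, a lower number a stronger inhibitor), compound 1 gives > 10000 nM, a limit of the assay rather than a number. Compound 2 `O=C(Nc1cc(F)cc2cccnc12)c1ncccn1` carries fluoro in the same place. In this assay compound 2 gives > 10000 nM, again a limit and not a number. Compound 2 thus sits at the limit of > 10000 nM in this assay, at which 2 of the 2 values shown sit. Compound 3 `O=C(Nc1cc(Cl)cc2cccnc12)c1ncccn1` differs from compound 2 by chloro in place of fluoro on an aromatic carbon. Within the data shown here, no measured pair isolates this change. In this assay the expected change is estimated as a step that the limit leaves unreadable from compound 2 to compound 3, nothing beyond the scatter. Compound 3 is estimated at 15000 nM, within 5000 nM to 50000 nM, most likely again reported only as a limit.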

Compound 3, half-maximal inhibitory concentration: > 10000 nM
Compound 3 was reported as a limit; the forecaster's own chance of this, stated with the estimate: 80%; the middle value is on the limit's open side.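

No step can be read between compound 3 and either compound 1 or compound 2 in this assay, where each value is a limit: the limit of > 10000 nM in this assay, at which 3 of the 3 values shown sit.

The compounds shown leave open whether chloro against fluoro, or pyrimidin-2-yl against pyrazin-2-yl, changes inhibition in this assay at all.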